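A Ring Swap on the Thiocarbonyl Carbon

This account rests on a few compounds, and the source may have more. Where it says the series, first, only, none or still open, it means among the compounds named here.

Three measured compounds share one core and differ only by a methyl group. Compound 1 `N/C(=N\NC(=S)N1CCOCC1)c1ccccn1` has no methyl; in a functional assay on A-431 cells (Homo sapiens) for cytotoxicity, read by MTT assay, with a stated time of 72 h, tested at 10 uM (a lower number here means less inhibition of growth, a higher number more inhibition of growth at the concentration tested), compound 1 gives 69.4%. Compound 2 `Cc1ccnc(/C(N)=N/NC(=S)N2CCOCC2)c1` carries a methyl in place of hydrogen on an aromatic carbon, and in this assay compound 2 gives 62%. Compound 3 `Cc1cccc(/C(N)=N/NC(=S)N2CCOCC2)n1` also carries a methyl in place of hydrogen on an aromatic carbon, and in this assay compound 3 gives 68.1%. The two steps are a number 7.4 percentage points lower from compound 1 to compound 2 (within the scatter) and a number 1.3 percentage points lower from compound 1 to compound 3 (within the scatter), both within the scatter, so compound 2 holds the lowest of the three numbers without standing apart from compound 1 or compound 3.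

Compound 4 `Cc1ccnc(/C(N)=N/NC(=S)N2CCCCC2)c1` is compound 2 with piperidin-1-yl in place of morpholin-4-yl on a thiocarbonyl carbon. Neither measured step touches this part of the molecule; both concern a methyl on an aromatic carbon, and neither moved the number beyond the scatter. Among the measured compounds shown here, no measured step therefore bears directly on the change. In this assay compound 4 is expected to give 62%, between 45% and 78%. The step of no change at the digits printed from compound 2 to compound 4 (within the scatter) is accordingly expected to stay within the scatter.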

Compound 4, percent growth inhibition at one concentration: 39.7%
Beside the measured number, compound 4's estimate is 22.3 percentage points above it, outside the stated range (below it).
By their numbers in this assay, from the lowest: compound 4; then compounds 2, 3 and 1 (each within the scatter of the next).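

In this assay the thiocarbonyl carbon proves to be a position where the read-out responds: putting piperidin-1-yl in place of morpholin-4-yl gives a number 22.3 percentage points lower from compound 2 to compound 4 (beyond the scatter), so less growth is inhibited at the concentration tested, whereas neither methyl step on an aromatic carbon left the scatter. The two groups have the same count of heavy atoms and differ in that morpholin-4-yl holds an oxygen and a hydrogen-bond acceptor that piperidin-1-yl lacks, so the result ties the drop to this one exchange within the ring. Nothing at hand explains why the number falls.

The step rests on a single pair, which leaves open whether the same exchange would count on the core of compound 1 or compound 3. Also open, on these data alone, is how a piperazine ring or an open-chain diethylamino group would read on this thiocarbonyl carbon.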